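Acetyl in place of hydrogen on the aryl ether

The compounds below may be only part of what the source reports. "The series", "measured", "known", "first", "only" and "open" are said of these compounds alone.

Compound 1, `O=C1OCC[C@@H]1NC(=S)SCCOc1ccc([N+](=O)[O-])cc1`: in a functional assay on PC-3 cells (Homo sapiens) for antiproliferative activity, read by MTT assay, with a stated time of 72 h (on this read-out lower numbers stand for stronger inhibition and higher numbers for weaker inhibition), compound 1 gives 32500 nM.
Compound 2, `O=C1OCC[C@@H]1NC(=S)SCCOc1ccccc1`: in this assay compound 2 gives > 64000 nM, which is a limit of the assay and not a number.
Compound 3, `O=C1OCC[C@@H]1NC(=S)SCCOc1ccccc1[N+](=O)[O-]`: in this assay compound 3 gives 24000 nM.

Going by the values given here, compound 2 therefore stands apart from the other two: only a limit is known for it, and it is the one value of the three that sits at the limit of > 64000 nM in this assay, at which 1 of the 3 values shown sits. Compound 4, `CC(=O)c1ccc(OCCSC(=S)N[C@H]2CCOC2=O)cc1`, differs from compound 2 by a single change, (acetyl in place of hydrogen on an aromatic carbon). Among the compounds with values here, two measured steps bear on this change, both of which exchange a hydrogen on the same aromatic ring for a nitro group. The first, an at least 1.9-fold higher number from compound 1 to compound 2 (0.29 log units; that floor lies within the scatter), rests on a floor that lies within the scatter. The second, an at least 2.6-fold lower number from compound 2 to compound 3 (0.42 log units; beyond the scatter), is beyond the scatter and at least modest. Both point the same way: a substituent on this ring goes with a lower number than the bare ring of compound 2. For compound 4 an acetyl group is expected to behave similarly, with a step of an at least 1.8-fold lower number from compound 2 to compound 4 (0.26 log units; that floor lies within the scatter) anticipated. Compound 4 is thus estimated at 35000 nM in this assay, within a range from 15000 nM to 80000 nM.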

Compound 4, half-maximal inhibitory concentration: 46900 nM
Estimate against measurement, compound 4: 1.3-fold (0.13 log units) below; low and high end bracket the measured number.
By their numbers in this assay, from the lowest: compounds 3, 1 and 4 (each within the scatter of the next). At a limit, above all of these: compound 2.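

Compound 4 puts a group other than nitro on the ring, and in this assay the step it gives (an at least 1.3-fold lower number from compound 2 to compound 4 (0.13 log units; that floor lies within the scatter)) has a floor within the scatter, so this step alone does not establish that acetyl lowers the number. The sharper comparison is with nitro on an aromatic carbon para to a large group: the step from nitro to acetyl (a 1.4-fold higher number from compound 1 to compound 4 (0.16 log units; within the scatter)) lies within the scatter, so this read-out does not separate the two groups at this position. The step from the bare ring can be read only as a floor, because compound 2 is known only as a limit of the assay: the limit of > 64000 nM in this assay, at which 1 of the 4 values shown sits.

The compounds shown leave open whether a smaller or quite different group at this position, such as an amine, a carboxylic acid or a methoxy group, would give a number in the same range as nitro and acetyl. They also leave open whether acetyl would match nitro at the place the nitro group holds in compound 3, and how far the bare ring of compound 2 truly lies from the substituted compounds.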